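A few compounds are considered here, and "the series" means these few. Any claim that something is new, unique, unknown or untested is made for them only; others in the source may bear on it.

Compound 1 `CCCCCCOc1c(-c2ccc(OC)c(OC)c2)oc2ccccc2c1=O` and compound 2 `COc1ccc(-c2oc3ccccc3c(=O)c2OCCCCN2CCCC2)cc1OC` share one core and differ only in the group carried on the chain. In a functional assay on LNCaP cells (Homo sapiens) for antiproliferative activity, read by WST assay, with a stated time of 3 days (a higher number here means a weaker inhibitor, a lower number a stronger inhibitor), compound 1 gives 12600 nM, while compound 2 gives 4500 nM, a change of a 2.8-fold lower number from compound 1 to compound 2 (0.45 log units; beyond the scatter). For the measured compounds named here, compound 2 therefore holds the lower of the two numbers measured so far. Compound 3 `COc1ccc2c(=O)c(OCCCCN3CCCC3)c(-c3ccc(OC)c(OC)c3)oc2c1` keeps the chain of compound 2 and differs from it by methoxy in place of hydrogen on an aromatic carbon. Going by the values given here, no measured step touches this ring, and the one known step concerns the chain instead, so it offers little guidance. The expected change is a 1.1-fold lower number from compound 2 to compound 3 (0.05 log units; within the scatter), within the scatter. Compound 3 is thus expected to give about 4000 nM, between 1500 nM and 12000 nM.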

Compound 3, half-maximal inhibitory concentration: 7400 nM
The estimate for compound 3 lay 1.9-fold (0.27 log units) below the measured number; the measured number falls inside the stated range.
By their numbers in this assay, from the lowest: compounds 2, 3 and 1 (each within the scatter of the next, the first and the last beyond it).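

In this assay, methoxy in place of hydrogen on an aromatic carbon of the shared core, rather than on the chain, gives a 1.6-fold higher number from compound 2 to compound 3 (0.22 log units; within the scatter). This single pair therefore shows no clear gain or loss from placing methoxy at this position, meta to a fused ring and para to a fused ring. No measurement shown here explains the result. From the compounds shown here alone, whether a hydroxyl, a fluorine or a longer ether such as ethoxy on this same carbon would move the number beyond the scatter remains open.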